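The source may report more compounds than this note shows. Statements on the series, on what has been measured and on what is new or still open speak of the compounds shown alone.

Compound 1, `CN1CCN(c2ccc(C3=NN(C(=O)c4ccc(C(F)(F)F)cc4)C(c4ccc(N(C)C)cc4)C3)cc2)CC1`: in a functional assay on HeLa cells (Homo sapiens) for inhibition (on this read-out higher numbers stand for weaker inhibition and lower numbers for stronger inhibition), compound 1 gives > 100000 nM, which is a limit of the assay and not a number.
Compound 2, `CN1CCN(c2ccc(C3=NN(S(=O)(=O)c4ccc(Br)cc4)C(c4ccc(N(C)C)cc4)C3)cc2)CC1`: in this assay compound 2 gives > 10000 nM, again a limit of the assay rather than a number.

On the numbers shown, compound 2 therefore stands at a limit, and compound 1 stands at a limit as well, so neither has a measured value. Among the measured compounds shown here, the single measured step, a step that the two limits leave unreadable from compound 1 to compound 2, cannot be read because the limit of > 10000 nM in this assay, at which 1 of the 2 values shown sits, and the limit of > 100000 nM in this assay, at which 1 of the 2 values shown sits, mark both of its ends. Compound 3, `CN1CCN(c2ccc(C3=NN(S(=O)(=O)c4ccc(C#N)cc4)C(c4ccc(N(C)C)cc4)C3)cc2)CC1`, differs from compound 2 by cyano in place of bromo on an aromatic carbon. For the measured compounds named here, only the step from compound 1 to compound 2 bears on this change, and it yields no readable size or direction, so no step beyond the scatter can be derived from it for the present change. Relative to compound 2, compound 3 is therefore expected to show a step that the limit leaves unreadable from compound 2 to compound 3, which is an estimate only. Compound 3 is expected to give 20000 nM, between 5000 nM and 100000 nM, and is most likely to be reported only as a limit.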

Compound 3, half-maximal inhibitory concentration: 3000 nM
Compound 3: middle estimate off by 6.7-fold (0.82 log units), on the high side; the measured number lies below the stated range.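

Cyano in place of bromo on the aromatic carbon, para to a large group, gives an at least 3.3-fold lower number from compound 2 to compound 3 (0.52 log units; beyond the scatter), which shows that in this assay the read-out responds to the group at this position. Replacing the (4-(trifluoromethyl)phenyl)carbonyl on the ring nitrogen with (4-cyanophenyl)sulfonyl gives an at least 33-fold lower number from compound 1 to compound 3 (1.52 log units; beyond the scatter), so a change at this nitrogen now has a readable lower bound, which the step from compound 1 to compound 2 could not provide. Both sizes are lower bounds only, because compound 2 and compound 1 each stand at a limit of the assay: the limit of > 10000 nM in this assay, at which 1 of the 3 values shown sits, and (the limit of > 100000 nM in this assay, at which 1 of the 3 values shown sits).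

From the compounds shown here alone, it remains open how far compound 2 truly lies from compound 3, and whether the lower number is specific to the nitrile or would also appear with an amine, a carboxylic acid or a methoxy group at this position. The compounds shown also do not separate the contributions of the sulfonyl link and the group on the aromatic ring, as the step from compound 1 to compound 3 changes both at once.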